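Cyclobutylamino for chloro on a fused purine-type core

The compounds below may be only part of what the source reports. "The series", "measured", "known", "first", "only" and "open" are said of these compounds alone.

Measured compounds:
compound 1, `Nc1nc(Cl)c2nnn([C@H]3CCCC[C@H]3CO)c2n1`: 95500 nM
compound 2, `OC[C@@H]1C[C@H](Cn2cnc3c(Cl)ncnc32)c2c(-c3ccccc3)nnc(-c3ccccc3)c21`: > 200000 nM

Of the compounds shown here, two have been measured in an ADME assay on L1210/0 cells (Mus musculus) for cytotoxicity, with a stated time of 48 h; on this read-out lower numbers stand for stronger inhibition and higher numbers for weaker inhibition. Compound 1, `Nc1nc(Cl)c2nnn([C@H]3CCCC[C@H]3CO)c2n1`, gives 95500 nM in this assay. For compound 2, `OC[C@@H]1C[C@H](Cn2cnc3c(Cl)ncnc32)c2c(-c3ccccc3)nnc(-c3ccccc3)c21`, this assay reports only a limit, > 200000 nM. Compound 2 therefore stands at the limit of > 200000 nM in this assay, at which 1 of the 2 values shown sits, so its place among the numbers cannot be fixed beyond that. Compound 3, `OC[C@@H]1C[C@H](Cn2cnc3c(NC4CCC4)ncnc32)c2c(-c3ccccc3)nnc(-c3ccccc3)c21`, is not yet measured; it differs from compound 2 by cyclobutylamino in place of chloro on an aromatic carbon. Among the measured compounds shown here, no step between measured compounds is available, so the effect of this change in this assay is unknown. A weak or no shift beyond the scatter is expected, with compound 3 estimated at 200000 nM (range 50000 nM to 600000 nM), which corresponds to an expected step of a number no higher from compound 2 to compound 3 (the limit leaves the size open), with a fair chance that only a limit is again reported.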

Compound 3, half-maximal inhibitory concentration: 90800 nM
Compound 3: the middle estimate sits 2.2-fold (0.34 log units) above what was measured, within the range that was stated.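

In this assay, putting cyclobutylamino in place of chloro on this aromatic carbon, next to the ring nitrogen, gives an at least 2.2-fold lower number from compound 2 to compound 3 (0.34 log units; beyond the scatter), so this position does respond to the group it carries. Among the compounds shown here, with no step available among the earlier compounds, this is the first sign that a change here can bring a compound from a limit to a measured number, towards stronger inhibition. The true size of the step stays open because compound 2 has only a limit in this assay: the limit of > 200000 nM in this assay, at which 1 of the 3 values shown sits.

The two compounds do not tell whether the amine nitrogen or the four-membered ring accounts for the shift. Going by these compounds, how a plain amino group, a longer chain such as n-butylamino or a methoxy group would read at this carbon remains open, as does whether the change carries over to another core.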